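The source may report more compounds than this note shows. Statements on the series, on what has been measured and on what is new or still open speak of the compounds shown alone.

Of the compounds shown here, three have been tested so far in a functional assay on HCT-116 cells (Homo sapiens) for cytotoxicity, read by sulforhodamine B assay, with a stated time of 48 h, tested at 100 uM; a lower number here means a stronger effect, a higher number a weaker effect of the compound at the concentration tested. Compound 3, `COc1ccc(-c2cc(/C=C/C(=O)c3ccc(N)cc3)[nH]n2)cc1OC`, gives -89% in this assay. Compound 1, `COc1cc(-c2cc(/C=C/C(=O)c3ccc(N)cc3)[nH]n2)cc(OC)c1OC`, differs from compound 3 by one change, (methoxy in place of hydrogen on an aromatic carbon), and in this assay compound 1 gives -73%. That single change made a step in this assay of a number 16 percentage points higher from compound 3 to compound 1 (beyond the scatter).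

Compound 2, `COc1ccc(C(=O)/C=C/c2cc(-c3cc(OC)c(OC)c(OC)c3)n[nH]2)cc1OC`, has a different core; the difference between the two cores of compound 2 and compound 3 is not broken down here. In this assay compound 2 gives -13%, which is the weakest effect of the three. The move between compound 1 and compound 2 made a step in this assay of a number 60 percentage points higher from compound 1 to compound 2 (beyond the scatter).

Compound 4, `COc1cc(C(=O)/C=C/c2cc(-c3cc(OC)c(OC)c(OC)c3)n[nH]2)cc(OC)c1OC`, has not yet been measured. It differs from compound 2 by methoxy in place of hydrogen on an aromatic carbon. Going by the values given here, this is the same change as the one from compound 3 to compound 1, made at a place described in the same words, but now on the core of compound 2. If it acts as before, a step in this assay of a number 15 percentage points higher from compound 2 to compound 4 (beyond the scatter) is expected, resting on the earlier step of a number 16 percentage points higher from compound 3 to compound 1 (beyond the scatter). Among the compounds with values here, for compound 4 the estimate in this assay is therefore 2%, with a likely range from -25% to 18%, the width reflecting that only one earlier example of this change is known.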

Compound 4, a percentage reported as activity, at one concentration (the size of the read-out at that concentration, not a potency): -88%
Beside the measured number, compound 4's estimate is 90 percentage points above it, outside the stated range (below it).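

In this assay the swap of hydrogen for methoxy on an aromatic carbon gave a number 75 percentage points lower from compound 2 to compound 4 (beyond the scatter) and so turned a weak effect into a much stronger one, whereas the same swap on the core of compound 3 slightly weakened the effect. Set side by side, the two steps run in opposite directions and clearly do not agree: the same change on two cores in this assay, a number 16 percentage points higher (beyond the scatter) from compound 3 to compound 1 and a number 75 percentage points lower (beyond the scatter) from compound 2 to compound 4, 91 percentage points apart, beyond the scatter of two such steps

This means that in this series, the size and even the direction of the methoxy step cannot simply be carried from one core to another, so each core has to be judged by its own measured numbers. Going by these compounds alone, with only two examples, the result does not show which feature of the cores lies behind the disagreement, nor which of the two steps is the more typical.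

The compounds shown leave open whether a hydroxy group or a longer ethoxy chain on that same aromatic carbon would also move the number in opposite directions on the two cores. They also leave open which way the methoxy step would go on a third core, and whether it would resemble either of the two steps seen here.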